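Ethoxy for Fluoro on a Quinoline Amide: Antiproliferative Read-out

The source may hold more compounds than are shown below. What is called first, only, known or untested is meant among the compounds shown, and "the series" means these compounds.

Measured compounds:
compound 1, `Cc1c(C(=O)Nc2c(F)cc(-c3cccc(F)c3)cc2F)nc2ccc(F)cc2c1O`, 0.86%
compound 2, `CCOc1ccc2nc(C(=O)Nc3c(F)cc(-c4cccc(F)c4)cc3F)c(C)c(O)c2c1`, 2.05%
compound 3, `Cc1c(C(=O)Nc2c(F)cc(-c3cccc(F)c3)cc2F)nc2ccc(F)cc2c1C(=O)O`, 3.02%

Three compounds were tested in a functional assay on A-375 cells (Homo sapiens) for antiproliferative activity, read by MTT assay, with a stated time of 24 h, tested at 0.41 ug/mL; a lower number here means a weaker effect, a higher number a stronger effect of the compound at the concentration tested. Compound 1 gives 0.86%, compound 2 gives 2.05% and compound 3 gives 3.02%; all three numbers lie close together, and the step of a number 2.2 percentage points higher from compound 1 to compound 3 (within the scatter) does not separate compound 1 from compound 3.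

Compound 3 differs from compound 1 in its core by carboxy in place of hydroxy on an aromatic carbon. Compound 2 arises from compound 1 by ethoxy in place of fluoro on an aromatic carbon, and in this assay that change gave a number 1.2 percentage points higher from compound 1 to compound 2 (within the scatter).

The unmeasured compound 4, `CCOc1ccc2nc(C(=O)Nc3c(F)cc(-c4cccc(F)c4)cc3F)c(C)c(C(=O)O)c2c1`, is made from compound 3 by ethoxy in place of fluoro on an aromatic carbon, the same change as from compound 1 to compound 2, at the same place.

Because the earlier instance produced a number 1.2 percentage points higher from compound 1 to compound 2 (within the scatter), a comparably small step, a number 1.2 percentage points higher from compound 3 to compound 4 (within the scatter), is expected in this assay for compound 4. On that basis compound 4 is estimated at 4.2%, with a likely range from -5% to 13%.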

Compound 4, a percentage reported as inhibition, at one concentration (the size of the read-out at that concentration, not a potency): 11.2%
Estimate against measurement, compound 4: 7 percentage points below; low and high end bracket the measured number.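

In this assay, ethoxy in place of fluoro on the core bearing carboxy gave a number 8.2 percentage points higher from compound 3 to compound 4 (within the scatter), and carboxy in place of hydroxy on the core bearing ethoxy gave a number 9.2 percentage points higher from compound 2 to compound 4 (within the scatter). The ethoxy change carried from one core to the other with no gap beyond the scatter: the same change on two cores in this assay, a number 1.2 percentage points higher (within the scatter) from compound 1 to compound 2 and a number 8.2 percentage points higher (within the scatter) from compound 3 to compound 4, 7 percentage points apart, within the scatter of two such steps. The carboxy change likewise carried across, though with every step inside the scatter, this does not show that either change truly raises the read-out, that the two changes add up, or that the steps on the two cores are equal: the same change on two cores in this assay, a number 2.2 percentage points higher (within the scatter) from compound 1 to compound 3 and a number 9.2 percentage points higher (within the scatter) from compound 2 to compound 4, 7 percentage points apart, within the scatter of two such steps.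

The compounds shown leave open whether a longer alkoxy chain or an amine in place of the fluoro, or an amide in place of the carboxy, would shift the read-out beyond the scatter. Also open, going by these compounds, is how these compounds behave at other concentrations, since each read-out here comes from a single one.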